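Ring Opened: From Cyclohexyl to Pentyl on the Ether Chain

The source may report more compounds than this note shows. Statements on the series, on what has been measured and on what is new or still open speak of the compounds shown alone.

Measured compounds:
compound 1, `CCCCCCOc1cc([N+](=O)[O-])ccc1NS(C)(=O)=O`, giving 2670 nM
compound 2, `CN(c1ccc([N+](=O)[O-])cc1OCC1CCCCC1)S(C)(=O)=O`, giving 960 nM

Both compounds were measured in an assay on SK-BR-3 cells for inhibition of Aromatase (Homo sapiens); a higher number here means a weaker inhibitor, a lower number a stronger inhibitor. Compound 2 stands lowest of the two numbers; the nearest, compound 1, lies higher by a margin that is beyond the usual scatter.

Compound 3, `CCCCCCOc1cc([N+](=O)[O-])ccc1N(C)S(C)(=O)=O`, has not yet been measured in this assay. It differs from compound 2 in one place: pentyl in place of cyclohexyl on a saturated chain carbon bound to an oxygen on an aromatic ring. Going by the values given here, no measured pair shows this change on its own, so the size of the step is open. The account expects a modest movement upward, that is a somewhat weaker inhibitor, though a result within the scatter of compound 2 is also plausible. For compound 3 the estimate is 1500 nM, with a range from 600 nM to 4000 nM. The estimated step is therefore a 1.6-fold higher number from compound 2 to compound 3 (0.19 log units; within the scatter).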

Compound 3, half-maximal inhibitory concentration: 4490 nM
For compound 3 the middle estimate is 3.0-fold (0.48 log units) below the measured one; the measured number lies above the stated range.
By their numbers in this assay, from the lowest: compound 2; then compounds 1 and 3 (each within the scatter of the next).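

In this assay, going by these compounds alone, replacing the cyclohexylmethyl on the ether oxygen with the open hexyl chain gives a 4.7-fold higher number from compound 2 to compound 3 (0.67 log units; beyond the scatter), the first reading of this change alone, and it shows that the ring-bearing group holds a real advantage over the open chain in compound 2. The other new pair, methyl in place of hydrogen on a sulfonamide nitrogen, gives a 1.7-fold higher number from compound 1 to compound 3 (0.23 log units; within the scatter), so with the hexyl chain in place this methyl has no effect that can be told from the scatter. Nothing at hand accounts for either result.

As far as these compounds go, whether a benzyl group or a longer chain on the same oxygen would match compound 2 remains open. So does whether the methyl on the sulfonamide nitrogen would also make no clear difference with cyclohexylmethyl on the oxygen.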